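The source may report more compounds than this note shows. Statements on the series, on what has been measured and on what is new or still open speak of the compounds shown alone.

Compound 3 `O=C(NC(=S)NNc1ncnc2ccccc12)c1ccc(Cl)cc1` carries a 4-chlorophenyl on the carbonyl carbon of the shared core. Within the data shown here, in a functional assay on KB cells (Homo sapiens) for cytotoxicity, read by MTT assay, with a stated time of 72 h (on this read-out lower numbers stand for stronger inhibition and higher numbers for weaker inhibition), compound 3 gives 3940 nM, the highest of the three numbers measured so far, though its separation from the other two stays within the scatter. Compound 1 `O=C(NC(=S)NNc1ncnc2ccccc12)c1ccccc1F` gives 2510 nM in this assay, and compound 2 `O=C(NC(=S)NNc1ncnc2ccccc12)c1ccccc1` gives 2330 nM. Compound 4 `O=C(NC(=S)NNc1ncnc2ccccc12)c1ccccc1Cl` differs from compound 3 in one respect: 2-chlorophenyl in place of 4-chlorophenyl on a carbonyl carbon.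

Among the measured compounds shown here, three measured steps bear on this change, since each alters the phenyl attached to the carbonyl carbon. The step of a 1.7-fold higher number from compound 2 to compound 3 (0.23 log units; within the scatter) is small, the step of a 1.1-fold lower number from compound 1 to compound 2 (0.03 log units; within the scatter) is smaller still, and the step of a 1.6-fold higher number from compound 1 to compound 3 (0.20 log units; within the scatter) also stays within the scatter. Nothing in these three compounds shows a substituent on this phenyl moving the number beyond the scatter in either direction, so no step beyond the scatter is expected for compound 4 in this assay.

The change that the estimate implies is expected to be a 1.4-fold lower number from compound 3 to compound 4 (0.13 log units; within the scatter), within the scatter. For compound 4 the expected number in this assay is 2900 nM, with a range from 1400 nM to 6000 nM.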

Compound 4, half-maximal inhibitory concentration: 7710 nM
Compound 4: the middle estimate sits 2.7-fold (0.42 log units) below what was measured; measured number above the stated range.
By their numbers in this assay, from the lowest: compounds 2, 1, 3 and 4 (each within the scatter of the next, the first and the last beyond it).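

In this assay the change from 4-chlorophenyl to 2-chlorophenyl on the carbonyl carbon gives a 2.0-fold higher number from compound 3 to compound 4 (0.29 log units; within the scatter), so these two chlorophenyl groups are not separated from each other by this result alone. Even so, compound 4 supplies the first steps beyond the scatter at this position: chloro in place of hydrogen gives a 3.3-fold higher number from compound 2 to compound 4 (0.52 log units; beyond the scatter) and chloro in place of fluoro gives a 3.1-fold higher number from compound 1 to compound 4 (0.49 log units; beyond the scatter), whereas the chloro of the 4-chlorophenyl group gave a 1.7-fold higher number from compound 2 to compound 3 (0.23 log units; within the scatter) and the exchange of fluoro for hydrogen gave a 1.1-fold lower number from compound 1 to compound 2 (0.03 log units; within the scatter), both within the scatter. Nothing shown here offers an explanation for these modest steps.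

The compounds shown leave open whether a bromo, methyl, methoxy or amine group in place of this chloro would also give a step beyond the scatter from the unsubstituted phenyl. They also leave open whether a second chloro on the same phenyl, or a carboxylic acid in its place, would move the number further in either direction.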